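The source may report more compounds than this note shows. Statements on the series, on what has been measured and on what is new or still open speak of the compounds shown alone.

Measured so far in a physicochemical assay for lipophilicity; a lower number here means a more polar compound, a higher number a more lipophilic compound:
compound 1 `CCCCCOc1ccc2[nH]c(-c3ccc(OC)cc3)c(C3=C(Br)C(=O)NC3=O)c2c1` gives 3.77
compound 2 `CCCCCCOc1ccc2[nH]c(-c3ccc(OC)cc3)c(C3=C(Br)C(=O)NC3=O)c2c1` gives 4.1
compound 3 `CCCc1ccc2[nH]c(-c3ccc(OC)cc3)c(C3=C(Br)C(=O)NC3=O)c2c1` gives 3.45

Compound 3 stands lowest of the three: a number 0.32 log units lower from compound 1 to compound 3 (beyond the scatter) and a number 0.65 log units lower from compound 2 to compound 3 (beyond the scatter). Compound 4 `CCCCc1ccc2[nH]c(-c3ccc(OC)cc3)c(C3=C(Br)C(=O)NC3=O)c2c1` awaits measurement. Its core is that of compound 3, which differs from the core of compound 1 by propyl in place of pentyloxy on an aromatic carbon.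

The change from compound 3 to compound 4 is methyl in place of hydrogen on a saturated chain carbon, three bonds along the chain from an aromatic carbon. The same kind of change was made from compound 1 to compound 2, (methyl in place of hydrogen on a saturated chain carbon, five bonds along the chain from an oxygen on an aromatic ring), and gave a number 0.33 log units higher from compound 1 to compound 2 (beyond the scatter). The places are not identical: in the earlier pair the chain runs from an oxygen on an aromatic ring, here from an aromatic carbon.

A step of about the earlier size is expected, a number 0.33 log units higher from compound 3 to compound 4 (beyond the scatter), because a number 0.33 log units higher from compound 1 to compound 2 (beyond the scatter). Compound 4 is estimated at 3.78, expected to fall between 3.55 and 4.05.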

Compound 4, partition coefficient: 3.83
Beside the measured number, compound 4's estimate is 0.05 log units below it; the measured number falls inside the stated range.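

In this assay, methyl in place of hydrogen on a saturated chain carbon carries across cores in direction: a number 0.38 log units higher from compound 3 to compound 4 (beyond the scatter) on the chain from an aromatic carbon, and a number 0.33 log units higher from compound 1 to compound 2 (beyond the scatter) on the chain from an oxygen on an aromatic ring. Butyl is not separated from either ether chain, with a number 0.27 log units lower from compound 2 to compound 4 (within the scatter) and a number 0.06 log units higher from compound 1 to compound 4 (within the scatter) for the two single-place comparisons. Two pairs do not show that the step holds on other cores or at other chain lengths, and no measurement bears on why it carries over.

Still open, on these data alone, is how the step behaves on a chain longer than hexyloxy. Also open, as far as these compounds go, is whether it survives on a chain ending in an amine or a carboxylic acid.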